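From 4-(trifluoromethyl)benzyl to 3-(trifluoromethyl)benzyl

The source may hold more compounds than are shown below. What is called first, only, known or untested is meant among the compounds shown, and "the series" means these compounds.

In a functional assay on B16 cells (Mus musculus) for antiproliferative activity, read by MTT assay, with a stated time of 24 h (a higher number here means a weaker inhibitor, a lower number a stronger inhibitor), compound 1 (`COc1cc(OC)c(-c2coc3cc(OCc4ccc(Br)cc4)ccc3c2=O)cc1OC`) gives 1180 nM and compound 2 (`COc1cc(OC)c(-c2coc3cc(OCc4ccc(C(F)(F)F)cc4)ccc3c2=O)cc1OC`) gives 5400 nM, the higher of the two numbers. Among the compounds with values here, the only measured step, a 4.6-fold higher number from compound 1 to compound 2 (0.66 log units; beyond the scatter), is modest and comes with trifluoromethyl in place of bromo on an aromatic carbon. Compound 3 (`COc1cc(OC)c(-c2coc3cc(OCc4cccc(C(F)(F)F)c4)ccc3c2=O)cc1OC`) has yet to be measured. It carries 3-(trifluoromethyl)phenyl in place of 4-(trifluoromethyl)phenyl on a saturated chain carbon bound to an oxygen on an aromatic ring. Within the data shown here, no measured step moves a group in this way, so the earlier step is only a rough guide to size. A change no larger than a 4.6-fold higher number from compound 1 to compound 2 (0.66 log units; beyond the scatter) is expected, leaning towards a lower number, and one within the scatter remains possible. The expected step is a 1.5-fold lower number from compound 2 to compound 3 (0.19 log units; within the scatter). For compound 3 the estimated value is 3500 nM, with an expected range from 1200 nM to 9000 nM.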

Compound 3, half-maximal inhibitory concentration: > 10000 nM
Compound 3: no number, only a limit (the forecaster's own chance of this, stated with the estimate: 5%); at least 2.8-fold (0.45 log units) between middle value and limit.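

In this assay compound 3 gives no number, only a limit of the assay: > 10000 nM. Putting 3-(trifluoromethyl)phenyl in place of 4-(trifluoromethyl)phenyl, with the same atoms joined differently, gives an at least 1.8-fold higher number from compound 2 to compound 3 (0.26 log units; that floor lies within the scatter), so the data do not set the two apart beyond the scatter, although the step points the same way as the earlier exchange of bromo for trifluoromethyl. Against 4-bromophenyl, the same 3-(trifluoromethyl)phenyl group gives an at least 8.4-fold higher number from compound 1 to compound 3 (0.92 log units; beyond the scatter), so both trifluoromethyl groups shown now give higher numbers than the bromo group.

As far as these compounds go, how a 3-bromophenyl group would compare with 4-bromophenyl and with 3-(trifluoromethyl)phenyl remains open. So does what a 4-methoxyphenyl group, a 4-cyanophenyl group or a longer chain in place of the benzyl carbon would give in this assay.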